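A few compounds are considered here, and "the series" means these few. Any claim that something is new, unique, unknown or untested is made for them only; others in the source may bear on it.

Compound 1 `CCc1cc(-c2noc(-c3cc(C)cc(CN(C)CC)c3)n2)cc(C)c1OC[C@@H](O)CNC(=O)CO` is the starting point. In an ADME assay on a cell-free system (plasma, Rattus norvegicus, strain Wistar) for protein binding, read by LC-MS, using equilibrium dialysis, with a stated time of 6 h (on this read-out higher numbers stand for a larger free fraction and lower numbers for a smaller free fraction), compound 1 gives 0.012. Among the three measured compounds, compound 1 is the only one with an actual number, as the other two sit at a limit (the limit of < 0.001 in this assay, at which 2 of the 3 values shown sit).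

Compound 2 `CCCCN(C)Cc1cc(C)cc(-c2nc(-c3cc(C)c(OC[C@@H](O)CNC(=O)CO)c(CC)c3)no2)c1` carries a longer chain on the amine. In this assay compound 2 returns only a limit, < 0.001. The change gives an at least 12-fold lower number from compound 1 to compound 2 (1.07 log units; beyond the scatter). Compound 3 `CCc1cc(-c2noc(-c3cc(C)cc(CN(C)CC(C)C)c3)n2)cc(C)c1OC[C@@H](O)CNC(=O)CO` carries a bulkier group on the amine. For compound 3 the result is again a limit, < 0.001. The change gives an at least 12-fold lower number from compound 1 to compound 3 (1.07 log units; beyond the scatter). Between these two, a step that the two limits leave unreadable from compound 2 to compound 3.

Compound 4 `CCc1cc(-c2noc(-c3cc(C)c(CN(C)C)s3)n2)cc(C)c1OC[C@@H](O)CNC(=O)CO` differs from compound 1 by 5-((dimethylamino)methyl)-4-methylthiophen-2-yl in place of 3-((ethyl(methyl)amino)methyl)-5-methylphenyl on an aromatic carbon. Among the measured compounds shown here, both measured steps, which enlarged the groups on the amine nitrogen, lowered the free fraction; in compound 4 those groups are instead both methyl, while the aromatic ring itself changes, for which no measured step exists. The step from compound 1 to compound 4 is therefore expected to be small, a 1.3-fold higher number from compound 1 to compound 4 (0.10 log units; within the scatter). Compound 4 is estimated at 0.015, within 0.005 to 0.04.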

Compound 4, unbound fraction: 0.012
Compound 4: middle estimate off by 1.3-fold (0.10 log units), on the high side, and the stated range covers the measured number.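

Swapping the whole group on this aromatic carbon, a six-membered carbon ring for a five-membered ring with one hetero atom, gives no change at the digits printed from compound 1 to compound 4 (within the scatter). So, unlike the two enlargements of the amine groups, this larger replacement keeps the unbound fraction in this assay away from the limit of the assay. The swap alters the ring, the placement of its substituents and the amine groups all at once, so their separate contributions cannot be told apart, and nothing measured here explains why the number holds.

Still open, going by these compounds, is what each part does alone: a dimethylamino group on the phenyl ring of compound 1, or an ethyl(methyl)amino group on the sulfur ring of compound 4, would separate them. Also open, on these data alone, is how a cyclic amine such as morpholine would read at this place on the amine side.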